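The source may report more compounds than this note shows. Statements on the series, on what has been measured and on what is new or still open speak of the compounds shown alone.

For the measured compounds named here, in an assay on isolated protein for inhibition of lysosomal alpha-glucosidase (Homo sapiens), tested at 1000 uM (on this read-out lower numbers stand for less inhibition and higher numbers for more inhibition at the one concentration tested (going by the name of the read-out)), three compounds have numbers so far. Compound 1 `Cc1ccc([C@]2(CO)NC[C@@H](O)[C@@H]2O)cc1` gives 21.3% and stands second highest of the three. The nearest number is that of compound 2 `OC[C@]1(c2c(F)c(F)c(F)c(F)c2F)NC[C@H](O)[C@H]1O`, which gives 6.9%, a gap beyond the usual scatter; the furthest is compound 3 `COc1cccc([C@@]2(CO)NC[C@H](O)[C@H]2O)c1`, which gives 46%, also beyond the scatter. Compound 4 `OC[C@@]1(c2ccccc2)NC[C@@H](O)[C@@H]1O` is not yet measured. It differs from compound 1 in one place: hydrogen in place of methyl on an aromatic carbon. Going by the values given here, no step between two measured compounds matches this change, so nothing in the set sets its direction. The step from compound 1 is expected to stay within the scatter, as a number 0.7 percentage points higher from compound 1 to compound 4 (within the scatter). Compound 4 is therefore expected to give 22% in this assay, between 8% and 40%.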

Compound 4, a percentage reported as inhibition, at one concentration (the size of the read-out at that concentration, not a potency): 35%
Compound 4: middle estimate off by 13 percentage points, on the low side; the range from low to high includes it.
By their numbers in this assay, from the lowest: compound 2; then compound 1; then compound 4; then compound 3.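

In this assay, for the compounds shown here, hydrogen in place of methyl on the aromatic carbon para to a group of 9 heavy atoms gives a number 13.7 percentage points higher from compound 1 to compound 4 (beyond the scatter) as the first one-place comparison in the set. This position therefore responds to the change, with hydrogen reading higher than methyl, though the step is modest. Nothing available bears on the reason for this step.

A single pair gives no trend across substituents at this carbon. Going by these compounds, whether an amine, a carboxylic acid or a longer alkyl chain there would read nearer to hydrogen or to methyl remains open.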